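The compounds below may be only part of what the source reports. "The series", "measured", "known", "first", "only" and "open" are said of these compounds alone.

Of the compounds shown here, two built on a shared core have been measured in a functional assay on HOS-TE85 cells (Homo sapiens) for inhibition, read by CCK-8 assay, with a stated time of 72 h; on this read-out lower numbers stand for stronger inhibition and higher numbers for weaker inhibition. Compound 1, `COc1ccccc1N1C(=O)CSC1c1cccc(C(=O)NCCCCn2cccn2)c1`, gives 91.7 nM in this assay. Compound 2, `O=C(NCCCCc1ccccc1)c1cccc(C2SCC(=O)N2c2cccc(F)c2)c1`, gives 32.4 nM in this assay, the lowest of the two numbers at hand; compound 1 stands higher, and the gap between them lies beyond the usual scatter, although the two structures differ in more than one place, so no single cause can be read from them. Compound 3, `Cc1cccc(N2C(=O)CSC2c2cccc(C(=O)NCCCCc3ccccc3)c2)c1`, has not yet been measured. For the measured compounds named here, the only change from compound 2 to compound 3 is methyl in place of fluoro on an aromatic carbon. Going by the values given here, no measured pair shows this exchange, so the expectation rests on the small size of the change. The expected step of a 1.1-fold higher number from compound 2 to compound 3 (0.03 log units; within the scatter) is small, within the scatter, and in no firm direction. Compound 3 is therefore estimated at 35 nM in this assay, with a range from 15 nM to 80 nM.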

Compound 3, half-maximal inhibitory concentration in the HOS-TE85 assay: 93.2 nM
Compound 3: middle estimate off by 2.7-fold (0.43 log units), on the low side; measured number outside the range, above it.
By their numbers in the HOS-TE85 assay, from the lowest: compound 2; then compounds 1 and 3 (each within the scatter of the next).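

In the HOS-TE85 assay, exchanging 3-fluorophenyl for 3-methylphenyl gives a 2.9-fold higher number from compound 2 to compound 3 (0.46 log units; beyond the scatter), so this place on the aromatic ring responds to a change of a single heavy atom, something the earlier pair, differing in more than one place, could not show. In a physicochemical assay for solubility, read by turbidimetry, measured as kinetic solubility, at pH 7.4 (a lower number here means a less soluble compound, a higher number a more soluble compound), compound 2 gives 10000 nM and compound 3 gives 10000 nM, which is no change at the digits printed from compound 2 to compound 3 (within the scatter), so the exchange that moves the inhibition number leaves the solubility number as it was. Nothing at hand explains the step in inhibition.

Going by these compounds, with only fluoro and methyl compared at this place, it remains open how a chloro or nitrile group, or a bare hydrogen, would read there. On these data alone, it is also open whether the same exchange would give a similar step on the side chain of compound 1.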